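Removing a Methyl from a Nitrophenyl Amide

The source may report more compounds than this note shows. Statements on the series, on what has been measured and on what is new or still open speak of the compounds shown alone.

Measured compounds:
compound 1 `O=C(CSc1nncnc1-c1cccc2ccccc12)Nc1ccccc1Br`: 87000 nM
compound 2 `O=C(CSc1nncnc1-c1cccc2ccccc12)N1CCc2ccccc2C1`: 13000 nM
compound 3 `Cc1ccc(NC(=O)CSc2nncnc2-c2cccc3ccccc23)c([N+](=O)[O-])c1`: 147000 nM

In an ADME assay on MT4 cells (Homo sapiens) for cytotoxicity, read by MTT assay (a higher number here means that more compound is tolerated, a lower number that less compound is tolerated), compound 3 gives the highest of the three numbers. Among the measured compounds shown here, its nearest neighbour is compound 1, the pair separated by a 1.7-fold higher number from compound 1 to compound 3 (0.23 log units; within the scatter); compound 2 stands furthest away, and the only step beyond the scatter is a 6.7-fold lower number from compound 1 to compound 2 (0.83 log units; beyond the scatter), which exchanged the whole amide partner.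

Compound 4 `O=C(CSc1nncnc1-c1cccc2ccccc12)Nc1ccccc1[N+](=O)[O-]` differs from compound 3 in one place: hydrogen in place of methyl on an aromatic carbon. For the measured compounds named here, no measured step removes a methyl, and the single step touching this ring, a 1.7-fold higher number from compound 1 to compound 3 (0.23 log units; within the scatter), lay within the scatter. Compound 4 is therefore expected to stay close to compound 3, with a step of a 1.2-fold lower number from compound 3 to compound 4 (0.09 log units; within the scatter) not beyond the scatter. The estimate for compound 4 is 120000 nM, within 55000 nM to 260000 nM.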

Compound 4, half-maximal cytotoxic concentration: 142000 nM
Estimate against measurement, compound 4: 1.2-fold (0.07 log units) below, within the range that was stated.
By their numbers in this assay, from the lowest: compound 2; then compounds 1, 4 and 3 (each within the scatter of the next).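

In this assay the methyl, meta to a nitro group and para to a large group, can be replaced by hydrogen with no change beyond the scatter (a 1.0-fold lower number from compound 3 to compound 4 (0.02 log units; within the scatter)). On the same amide, nitro in place of bromo also stays within the scatter (a 1.6-fold higher number from compound 1 to compound 4 (0.21 log units; within the scatter)), whereas (2-nitrophenyl)amino in place of 1,2,3,4-tetrahydroisoquinolin-2-yl gives a large step (an 11-fold higher number from compound 2 to compound 4 (1.04 log units; beyond the scatter)). No evidence is available that accounts for these steps. On these data alone, whether an amine or a carboxylic acid on this aromatic carbon would also stay within the scatter remains open.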